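The source may report more compounds than this note shows. Statements on the series, on what has been measured and on what is new or still open speak of the compounds shown alone.

Measured so far in a functional assay on PC-3 cells (Homo sapiens) for antiproliferative activity, read by MTT assay, tested at 5 uM; a lower number here means a weaker effect, a higher number a stronger effect of the compound at the concentration tested:

compound 1 `COc1cc(C(=O)N/N=C/c2ccccc2C(F)(F)F)cc(OC)c1OC`: 52.9%
compound 2 `COc1cccc(/C=N/NC(=O)c2cc(OC)c(OC)c(OC)c2)c1OC`: 67%

Compound 1 stands at the lower of the two numbers. Going by the values given here, compound 2 sits a gap above it that lies beyond the scatter, so the two values can be told apart in this assay, though with only two compounds no pattern can be drawn from them.

Compound 3 `COc1cc(C(=O)N/N=C/c2ccccc2F)cc(OC)c1OC` is not yet measured. It differs from compound 1 in one place: fluoro in place of trifluoromethyl on an aromatic carbon. The shared core and the hydrazone linker are unchanged. Among the compounds with values here, no measured pair shows what this exchange does in this assay, so the size and direction of the step are unknown from the data at hand.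

The expectation for compound 3 is a value close to that of compound 1, with a step from compound 1 a number 2.9 percentage points lower from compound 1 to compound 3 (within the scatter) that is not expected to exceed the scatter in either direction. Compound 3 is estimated at 50%, with a range from 32% to 68%.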

Compound 3, a percentage reported as inhibition, at one concentration (the size of the read-out at that concentration, not a potency): 81.8%
The estimate for compound 3 lay 31.8 percentage points below the measured number; the whole stated range lies below it.
By their numbers in this assay, from the lowest: compound 1; then compound 2; then compound 3.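

Fluoro in place of trifluoromethyl on an aromatic carbon, ortho to a large group, gives in this assay a number 28.9 percentage points higher from compound 1 to compound 3 (beyond the scatter), the first measured one-place step in the series. The read-out at this position therefore responds to the substituent, and the group with 1 heavy atom gives the higher number of this pair, while neither group carries hydrogen-bond donors or acceptors. No measured property of either compound bears on this step, so its origin remains unassigned.

A single pair cannot separate the number of heavy atoms from the identity of the group, and a chlorine, a methyl or an amine on the same carbon would help to tell these apart. As far as these compounds go, whether the same exchange gives a similar step on another carbon of the ring also remains open.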